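Replacing 2-bromophenyl with 3-hydroxyphenyl in compound 3

The source may hold more compounds than are shown below. What is called first, only, known or untested is meant among the compounds shown, and "the series" means these compounds.

In a functional assay on MCF7 cells (Homo sapiens) for cytotoxicity, read by MTT assay, with a stated time of 72 h (a higher number here means a weaker inhibitor, a lower number a stronger inhibitor), compound 1 (`COc1ccccc1/C=C1\CCC/C(=C\c2cccc(OC)c2OC)C1=O`) gives 12000 nM, compound 2 (`COc1cc(/C=C2\CCC/C(=C\c3cccc(OC)c3OC)C2=O)ccc1O`) gives 11600 nM and compound 3 (`COc1ccc(/C=C2\CCC/C(=C\c3ccccc3Br)C2=O)cc1OC`) gives 9500 nM. These three values lie within the usual scatter of one another, so compound 3 stands level with the other two. Compound 4 (`COc1ccc(/C=C2\CCC/C(=C\c3cccc(O)c3)C2=O)cc1OC`) differs from compound 3 in one place, on a double-bonded chain carbon bound to a double-bonded ring carbon: 3-hydroxyphenyl in place of 2-bromophenyl on a double-bonded chain carbon bound to a double-bonded ring carbon. Going by the values given here, the one measured step that also exchanges such a group, 4-hydroxy-3-methoxyphenyl in place of 2-methoxyphenyl, was a 1.0-fold lower number from compound 1 to compound 2 (0.01 log units; within the scatter). No change beyond the scatter is therefore expected in this assay, and the estimated step is a 1.1-fold higher number from compound 3 to compound 4 (0.02 log units; within the scatter). Compound 4 is expected at 10000 nM, with an estimated range of 5000 nM to 20000 nM.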

Compound 4, half-maximal inhibitory concentration: 2900 nM
Compound 4: the middle estimate sits 3.4-fold (0.54 log units) above what was measured; the measured number lies below the stated range.
By their numbers in this assay, from the lowest: compound 4; then compounds 3, 2 and 1 (each within the scatter of the next).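

Going by these compounds alone, this exchange of 3-hydroxyphenyl for 2-bromophenyl gives a 3.3-fold lower number from compound 3 to compound 4 (0.52 log units; beyond the scatter) in this assay, the first step here to pass beyond the scatter. The earlier exchange, a 1.0-fold lower number from compound 1 to compound 2 (0.01 log units; within the scatter), did not pass it, so the group on this double-bonded chain carbon can change the number, though not every exchange does. From the compounds shown here alone, whether the lower number follows the loss of bromine or the arrival of the hydroxy group stays open, as does how a 3-aminophenyl group would read at this place. No measurement shown explains the shift.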